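Amide-linked thioether series: notes toward compound 4

This account rests on a few compounds, and the source may have more. Where it says the series, first, only, none or still open, it means among the compounds named here.

Values in a functional assay on MCF7 cells (Homo sapiens) for cytotoxicity, read by MTT assay, with a stated time of 24 h, tested at 6.4 ug/mL (a lower number here means a weaker effect, a higher number a stronger effect of the compound at the concentration tested), for the three measured compounds:
compound 1 `Cn1c(-c2ccc(NC(=O)CCl)cc2)nc(-c2ccccc2)c1-c1ccccc1`: 14.2%
compound 2 `Cn1c(-c2ccc(NC(=O)CSc3nc4ccccc4o3)cc2)nc(-c2ccccc2)c1-c1ccccc1`: 42.3%
compound 3 `Cn1c(-c2ccc(NC(=O)CSc3nc4ccccc4s3)cc2)nc(-c2ccccc2)c1-c1ccccc1`: 27%

Compound 3 stands second highest of the three; its nearest neighbour is reached by a number 12.8 percentage points higher from compound 1 to compound 3 (beyond the scatter) and its furthest by a number 15.3 percentage points lower from compound 2 to compound 3 (beyond the scatter). Compound 4 `Cn1cnnc1SCC(=O)Nc1ccc(-c2nc(-c3ccccc3)c(-c3ccccc3)n2C)cc1` differs from compound 3 by 4-methyl-4H-1,2,4-triazol-3-yl in place of 1,3-benzothiazol-2-yl on a sulfur. For the measured compounds named here, the one comparable exchange of the group on the sulfur gave a number 15.3 percentage points lower from compound 2 to compound 3 (beyond the scatter), a modest step; replacing chloro by a heteroarylsulfanyl gave a number 28.1 percentage points higher from compound 1 to compound 2 (beyond the scatter) and a number 12.8 percentage points higher from compound 1 to compound 3 (beyond the scatter). Going by the values given here, for the triazolyl there is no direct precedent, so a step of at most modest size, direction uncertain, is expected in this assay: a number 3 percentage points lower from compound 3 to compound 4 (within the scatter). Compound 4 is therefore estimated at 24%, within 10% to 42%.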

Compound 4, a percentage reported as activity, at one concentration (the size of the read-out at that concentration, not a potency): 59.2%
For compound 4 the middle estimate is 35.2 percentage points below the measured one; the whole stated range lies below it.
By their numbers in this assay, from the lowest: compound 1; then compound 3; then compound 2; then compound 4.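

In this assay, the group on the sulfur matters more than the earlier exchange showed: 4-methyl-4H-1,2,4-triazol-3-yl, with one ring, gives a number 32.2 percentage points higher from compound 3 to compound 4 (beyond the scatter) and a number 16.9 percentage points higher from compound 2 to compound 4 (beyond the scatter) against the two-ring groups. Compound 4 thus stands highest of the four, and a number 45 percentage points higher from compound 1 to compound 4 (beyond the scatter) is the largest gain over chloro in the series. Nothing at hand accounts for this rise.

As far as these compounds go, whether it depends on the methyl or on the ring itself stays open. So does whether a tetrazolyl, an imidazolyl or a dimethylaminoethyl group on the sulfur would keep it.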